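The source may report more compounds than this note shows. Statements on the series, on what has been measured and on what is new or still open speak of the compounds shown alone.

Compound 1 `O=C1C(Nc2ccc(-c3ccc(Cl)cc3)cc2)=CC(=O)c2ncncc21` gives 9700 nM
Compound 2 `CCc1ccc(-c2ccc(NC3=CC(=O)c4ncncc4C3=O)cc2)cc1` gives 1500 nM
Compound 3 `O=C1C(Nc2ccc(-c3cc(Cl)cc(Cl)c3)cc2)=CC(=O)c2ncncc21` gives 3100 nM

In a functional assay on MIA PaCa-2 cells (Homo sapiens) for cytotoxicity, read by MTT assay, with a stated time of 72 h (on this read-out lower numbers stand for stronger inhibition and higher numbers for weaker inhibition), compound 3 at 3100 nM lies in the middle of the three numbers, with (a 2.1-fold higher number from compound 2 to compound 3 (0.32 log units; beyond the scatter)) on one side and (a 3.1-fold lower number from compound 1 to compound 3 (0.50 log units; beyond the scatter)) on the other. Compound 4 `O=C1C(Nc2ccc(-c3ccccn3)cc2)=CC(=O)c2ncncc21` carries pyridin-2-yl in place of 3,5-dichlorophenyl on an aromatic carbon. Among the measured compounds shown here, all the measured steps change this same outer group, and even the largest (a 6.5-fold lower number from compound 1 to compound 2 (0.81 log units; beyond the scatter)) is modest. None of them introduces a ring nitrogen, so they show no direction, and in this assay no more than a modest step either way is expected. The estimated step is small (a 1.3-fold higher number from compound 3 to compound 4 (0.11 log units; within the scatter)). For compound 4 the expected value is 4000 nM (estimated range 1200 nM to 13000 nM).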

Compound 4, half-maximal inhibitory concentration: 2000 nM
Beside the measured number, compound 4's estimate is 2.0-fold (0.30 log units) above it, and the stated range covers the measured number.
By their numbers in this assay, from the lowest: compounds 2, 4 and 3 (each within the scatter of the next, the first and the last beyond it); then compound 1.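

In this assay, pyridin-2-yl, the only outer ring here with a ring nitrogen, stays level with the 3,5-dichlorophenyl ring (a 1.6-fold lower number from compound 3 to compound 4 (0.19 log units; within the scatter)) and with 4-ethylphenyl (a 1.3-fold higher number from compound 2 to compound 4 (0.12 log units; within the scatter)), so at this place the nitrogen costs nothing measurable against these two groups. Only against 4-chlorophenyl does it stand apart (a 4.9-fold lower number from compound 1 to compound 4 (0.69 log units; beyond the scatter)), which leaves compound 1 alone at the high end. Nothing available here accounts for this. From the compounds shown here alone, it remains open whether pyridin-3-yl or pyridin-4-yl would match pyridin-2-yl, and whether an amine or a carboxylic acid on the outer ring would shift the number.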